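A few compounds are considered here, and "the series" means these few. Any claim that something is new, unique, unknown or untested is made for them only; others in the source may bear on it.

Measured compounds in an assay on isolated protein for binding affinity to Adrenergic receptor alpha-1 (Rattus norvegicus), read by radioligand binding; a higher number here means a weaker inhibitor, a lower number a stronger inhibitor:

compound 1 `O=C1C2CCCCN2C(=O)N1CN1CCN(c2cccc(Cl)c2)CC1`, 135 nM
compound 2 `O=C1C2CCCCN2C(=O)N1CN1CCN(c2ccc(F)cc2)CC1`, 869 nM
compound 3 `O=C1C2CCCCN2C(=O)N1CCN1CCN(c2cccc(Cl)c2)CC1`, 375 nM

Compound 1 and compound 3 share the same outer substituent; the difference between the two cores is not broken down here. Compound 2 carries the change (4-fluorophenyl in place of 3-chlorophenyl on an amine nitrogen in a ring), and that step gave a 6.4-fold higher number from compound 1 to compound 2 (0.81 log units; beyond the scatter).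

Compound 4 `O=C1C2CCCCN2C(=O)N1CCN1CCN(c2ccc(F)cc2)CC1` is not yet measured. It carries the change (4-fluorophenyl in place of 3-chlorophenyl on an amine nitrogen in a ring), the same change as before, on the same place. The expectation for compound 4 in this assay rests on the step already seen, a 6.4-fold higher number from compound 1 to compound 2 (0.81 log units; beyond the scatter), applied to compound 3; a step of about a 6.4-fold higher number from compound 3 to compound 4 (0.81 log units; beyond the scatter) is expected. On that basis compound 4 is estimated at 2400 nM, with a likely range from 1000 nM to 5500 nM.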

Compound 4, inhibition constant: > 1000 nM
Compound 4 ended at the assay's limit; the forecaster's own chance of this, stated with the estimate: 5%; the middle value is on the limit's open side.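

The change to 4-fluorophenyl in place of 3-chlorophenyl gives a higher number in this assay on the second core as well, an at least 2.6-fold higher number from compound 3 to compound 4 (0.42 log units; beyond the scatter). Compound 4 stands at > 1000 nM, which is a limit of the assay and not a number. The direction of the change therefore carries from one core to the other, but this pair does not show whether its size carries too: the same change on two cores in this assay, a 6.4-fold higher number (0.81 log units; beyond the scatter) from compound 1 to compound 2 and an at least 2.6-fold higher number (0.42 log units; beyond the scatter) from compound 3 to compound 4; the limit leaves it open whether they differ

The compounds shown leave open whether the result follows from the swap of chlorine for fluorine or from the different placing of the halogen on the phenyl ring. Also open, as far as these compounds go, is how an unsubstituted phenyl or a methoxyphenyl group would read on either core, and how a longer chain to the core would read.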